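Swapping the Anilino Group for 4-Chlorophenyl

This account rests on a few compounds, and the source may have more. Where it says the series, first, only, none or still open, it means among the compounds named here.

Measured compounds:
compound 1 `C=C[C@@](C)(/C=C/c1ccc(Nc2ccccc2)cc1)CCC=C(C)C` gives > 36600 nM
compound 2 `C=C[C@@](C)(/C=C/c1ccc(Nc2cccc(C(F)(F)F)c2)cc1)CCC=C(C)C` gives > 36600 nM

In a functional assay on SEM cells (Homo sapiens) for cytotoxicity, with a stated time of 72 h (a higher number here means that more compound is needed for the effect, a lower number that less compound is needed), compound 1 gives > 36600 nM, which is a limit of the assay rather than a number. Compound 2 likewise gives only a limit, > 36600 nM. The step that the two limits leave unreadable from compound 1 to compound 2 cannot be read because of the limit of > 36600 nM in this assay, at which 2 of the 2 values shown sit. Compound 3 `C=C[C@@](C)(/C=C/c1ccc(-c2ccc(Cl)cc2)cc1)CCC=C(C)C` differs from compound 1 by 4-chlorophenyl in place of anilino on an aromatic carbon. No readable measured step bears on this change, so nothing points to a shift in either direction. Compound 3 is expected to give 50000 nM, within 15000 nM to 200000 nM. The expected step that the limit leaves unreadable from compound 1 to compound 3 is estimated as none beyond the scatter.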

Compound 3, half-maximal effective concentration: > 36600 nM
Compound 3 gave a limit, no number (the forecaster's own chance of this, stated with the estimate: 80%); the middle value does not contradict the limit.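

Compound 3, like compound 1, gives only a limit in this assay, so no step between compound 1 and compound 3 can be read: the limit of > 36600 nM in this assay, at which 3 of the 3 values shown sit.

On these data alone, whether any group on the shared core would give an actual number in this assay stays open.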